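From Hydrogen to Methoxy on Compound 1

A few compounds are considered here, and "the series" means these few. Any claim that something is new, unique, unknown or untested is made for them only; others in the source may bear on it.

In an ADME assay for permeability, using PAMPA, at pH 4 (a lower number here means that the compound crosses the layer more slowly, a higher number that the compound crosses the layer faster), compound 1 `Cc1[nH]c2ccccc2c(=O)c1Cc1ccccc1` gives 110 10^-6 cm/s. Going by the values given here, this is the lower of the two numbers measured so far, the other being compound 2 `Cc1[nH]c2ccc(Cl)cc2c(=O)c1Cc1ccccc1` at 422 10^-6 cm/s.

Compound 3 `COc1cccc2c(=O)c(Cc3ccccc3)c(C)[nH]c12` keeps the core of compound 1 and carries one change: methoxy in place of hydrogen on an aromatic carbon. In words, this is methoxy in place of hydrogen on an aromatic carbon, and the new group sits ortho to a fused ring.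

Among the compounds with values here, only one measured step bears on this change: a 3.8-fold higher number from compound 1 to compound 2 (0.58 log units; beyond the scatter). That step is chloro in place of hydrogen on an aromatic carbon. Within the data shown here, it involves a different group, and no methoxy compound on this core has a measured number yet, so it offers only a loose guide. The direction is therefore expected to be upward, but the size is expected to be smaller than that of the chloro step and may not clear the scatter.

The expected change is a 1.5-fold higher number from compound 1 to compound 3 (0.19 log units; within the scatter). For compound 3, the estimate is 170 10^-6 cm/s, with an expected range from 70 10^-6 cm/s to 420 10^-6 cm/s.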

Compound 3, apparent permeability: 164 10^-6 cm/s
The estimate for compound 3 lay 1.0-fold (0.02 log units) above the measured number, and the stated range covers the measured number.
By their numbers in this assay, from the lowest: compounds 1 and 3 (each within the scatter of the next); then compound 2.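

In this assay, methoxy in place of hydrogen on an aromatic carbon, ortho to a fused ring, gives a 1.5-fold higher number from compound 1 to compound 3 (0.17 log units; within the scatter), so the numbers for these two compounds cannot be told apart. Going by these compounds alone, this is a different outcome from the only earlier step, a 3.8-fold higher number from compound 1 to compound 2 (0.58 log units; beyond the scatter), and it shows that replacing a hydrogen on an aromatic carbon of this core does not always move the number beyond the scatter. The data shown offer no measurement that would explain why the methoxy step stays within the scatter while the chloro step does not.

Compound 2 and compound 3 differ in more than one place, so these two steps cannot separate the effect of the group from the effect of where it sits. As far as these compounds go, it remains open whether methoxy on the carbon that carries chloro in compound 2, or chloro on the carbon that carries methoxy in compound 3, would behave differently, and whether an amine or a longer chain such as ethoxy at the methoxy position would give a step beyond the scatter.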